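Adding One Methyl to a Shared Core: Four Compounds

This account rests on a few compounds, and the source may have more. Where it says the series, first, only, none or still open, it means among the compounds named here.

Compound 1 `CC(Cn1ncccc1=O)C(=N)S` and compound 2 `CC(CC(=N)S)n1ncccc1=O` are built from the same atoms joined differently; the difference between the two cores is not broken down here. Compound 3 `Cc1ccc(=O)n(CC(C)C(=N)S)n1` arises from compound 1 by one change, (methyl in place of hydrogen on an aromatic carbon). Compound 4 `Cc1ccc(=O)n(C(C)CC(=N)S)n1` has not yet been measured and arises from compound 2 by the same change, (methyl in place of hydrogen on an aromatic carbon). The surroundings of the place of change are described in the same words for both pairs, so this is the same change made on two cores.

The three measured compounds were tested in a functional assay on the whole organism (stomach) with Rattus norvegicus as the target; a higher number here means that more compound is needed for the effect, a lower number that less compound is needed. Compound 1 gives only a limit of the assay in this assay, > 100 mg/kg. Compound 2 likewise gives only a limit, > 100 mg/kg. Compound 3 also gives only a limit, > 100 mg/kg. The measured step is therefore a step that the two limits leave unreadable from compound 1 to compound 3; its size stays hidden because of the limit of > 100 mg/kg in this assay, at which 3 of the 3 values shown sit.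

For compound 4 the step in this assay is expected to be a step that the limit leaves unreadable from compound 2 to compound 4. That expectation rests on compound 1 and compound 3, whose step that the two limits leave unreadable from compound 1 to compound 3 gives no sign of a readable shift, and on compound 2 sitting at the same limit, > 100 mg/kg. Compound 4 is thus expected to give roughly 250 mg/kg in this assay, most probably again only as a limit, somewhere between 100 mg/kg and 800 mg/kg.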

Compound 4, dose for half-maximal effect: > 100 mg/kg
Compound 4 ended at the assay's limit (the forecaster's own chance of this, stated with the estimate: 85%); the middle value is on the limit's open side.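

Compound 2 and compound 4 both end at a limit of the assay and not at a number, so the step between them cannot be read, just as for compound 1 and compound 3: the limit of > 100 mg/kg in this assay, at which 4 of the 4 values shown sit. The compounds shown leave open whether the methyl shifts the dose needed in this assay on either core, and whether any such shift would match across the two cores.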